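The source may report more compounds than this note shows. Statements on the series, on what has been measured and on what is new or still open speak of the compounds shown alone.

Compound 1 `Cc1cc(/C=C/c2ccc(O)cc2)[nH]n1`: 80000 nM
Compound 2 `COc1ccc(/C=C/c2cc(C)no2)cc1OC`: 44700 nM
Compound 3 `COc1cc(/C=C/c2cc(C)[nH]n2)ccc1O`: 35400 nM

All three compounds were tested in an ADME assay on MDCK cells (Canis lupus familiaris) for cytotoxicity, read by MTT assay, with a stated time of 72 h (a higher number here means a weaker inhibitor, a lower number a stronger inhibitor), and all three carry a five-membered aromatic ring. In this set, compound 2 gives 44700 nM, a value within the usual scatter of the values for compound 1 and compound 3. No two of the measured compounds differ in only one place, so the data offer no direct measure of what a single change does.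

The next compound, compound 4 `COc1ccc(/C=C/C(=O)CC(C)=O)cc1OC`, departs from compound 2 at one place: (2-oxopropyl)carbonyl in place of 3-methyl-1,2-oxazol-5-yl on a double-bonded chain carbon bound to a double-bonded chain carbon. In words, (2-oxopropyl)carbonyl stands in place of 3-methyl-1,2-oxazol-5-yl on a double-bonded chain carbon bound to a double-bonded chain carbon. Going by the values given here, the incoming group has no ring, and no measured compound shows what losing the ring does in this assay, so any forecast is uncertain.

Starting from compound 2 at 44700 nM, a modest move towards a lower number seems the most likely outcome, though it may not clear the scatter. The expected move is a 1.8-fold lower number from compound 2 to compound 4 (0.25 log units; within the scatter). The estimated value for compound 4 is 25000 nM, with an expected range from 8000 nM to 80000 nM.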

Compound 4, half-maximal inhibitory concentration: 9900 nM
Beside the measured number, compound 4's estimate is 2.5-fold (0.40 log units) above it, and the stated range covers the measured number.
By their numbers in this assay, from the lowest: compound 4; then compounds 3, 2 and 1 (each within the scatter of the next, the first and the last beyond it).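

In this assay, going by these compounds alone, (2-oxopropyl)carbonyl in place of 3-methyl-1,2-oxazol-5-yl on a double-bonded chain carbon bound to a double-bonded chain carbon gives a 4.5-fold lower number from compound 2 to compound 4 (0.65 log units; beyond the scatter), the first single-place step in this set and one that lies beyond the scatter. It shows that the number responds to what this position carries: the two groups match in heavy-atom count, hydrogen-bond donors, hydrogen-bond acceptors and net charge, yet the open-chain group gives the lower number. Nothing measured here bears on the reason for this step.

With a single exchange at this position, the compounds shown leave open whether the lower number goes with the loss of the ring or with the carbonyl groups of the incoming chain, and whether an acetyl group, a carboxylic acid or an amine in the same place would move the number the same way. They also leave open whether the same exchange would give a step of similar size starting from compound 3, whose five-membered aromatic ring differs from that of compound 2.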